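The source may report more compounds than this note shows. Statements on the series, on what has been measured and on what is new or still open speak of the compounds shown alone.

Measured compounds:
compound 1 `Cc1noc(C)c1S(=O)(=O)N1CCC(N2CCC(C)CC2)CC1` — > 5000 nM (a limit of the assay)
compound 2 `CC1CCN(C2CCN(S(=O)(=O)c3cc(Br)cc4c3OCC4)CC2)CC1` — 96 nM
compound 3 `C#CCOCCC1CCCCN1C1CCN(S(=O)(=O)c2ccccc2)CC1` — > 5000 nM (a limit of the assay)

In a functional assay on DLD-1 cells (Homo sapiens) for antiproliferative activity, read by CellTiter-Glo, with a stated time of 72 h (on this read-out higher numbers stand for weaker inhibition and lower numbers for stronger inhibition), compound 1 gives only a limit, > 5000 nM. Compound 3 likewise gives only a limit, > 5000 nM. Compound 2 gives a number, 96 nM, and it shares the core of compound 1 with a different group on the sulfonyl sulfur. Two of the three values shown sit at the limit of > 5000 nM in this assay, at which 2 of the 3 values shown sit. Compound 4 `CC1CCN(C2CCN(S(=O)(=O)c3ccc(Cl)nc3)CC2)CC1` is not yet measured in this assay. It differs from compound 1 by 6-chloropyridin-3-yl in place of 3,5-dimethyl-1,2-oxazol-4-yl on a sulfonyl sulfur. Among the compounds with values here, no measured pair shows this kind of change, so the expected step of an at least 2.0-fold lower number from compound 1 to compound 4 (0.30 log units; that floor lies within the scatter) is uncertain in direction and could reach beyond the scatter. For compound 4 the estimate in this assay is 2500 nM, within 300 nM to 10000 nM.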

Compound 4, half-maximal inhibitory concentration: 3700 nM
The estimate for compound 4 lay 1.5-fold (0.17 log units) below the measured number; low and high end bracket the measured number.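

Within the data shown here, putting 6-chloropyridin-3-yl in place of 3,5-dimethyl-1,2-oxazol-4-yl on the sulfonyl sulfur gives an at least 1.3-fold lower number from compound 1 to compound 4 (0.13 log units; that floor lies within the scatter) and so a step at this position that the earlier compounds did not offer. Compound 1 gives only a limit of the assay (> 5000 nM). Going by these compounds, the step is therefore only a floor, and its true size stays unknown because compound 1 sits at that limit: the limit of > 5000 nM in this assay, at which 2 of the 4 values shown sit.

Still open is what the chlorine contributes, since neither an unsubstituted pyridin-3-yl nor a 6-methylpyridin-3-yl on the sulfonyl sulfur appears among these compounds.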